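The source may hold more compounds than are shown below. What is called first, only, known or untested is meant among the compounds shown, and "the series" means these compounds.

Measured so far, in a functional assay on A549 cells (Homo sapiens) for antiproliferative activity, read by MTT assay, with a stated time of 72 h; on this read-out higher numbers stand for weaker inhibition and lower numbers for stronger inhibition:
compound 1, `O=C(Nc1cccc(Br)c1)C(Cl)Cl`: 7800 nM
compound 2, `O=C(Nc1cccc(I)c1)C(Cl)Cl`: 4760 nM
compound 3, `O=C(Nc1ccc(Br)cc1)C(Cl)Cl`: 13700 nM

All three are dichloroacetamides of a halogenated aniline. Compound 1 and compound 2 share one core; their difference is iodo in place of bromo on an aromatic carbon, and the step is a 1.6-fold lower number from compound 1 to compound 2 (0.21 log units; within the scatter). Compound 3 has the same atoms as compound 1 joined differently; how the two cores differ is not broken down here. Compound 3 gives the highest number of the three; against compound 1 the gap is within the scatter, while against compound 2 it lies beyond it.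

Compound 4, `O=C(Nc1ccc(I)cc1)C(Cl)Cl`, has not yet been measured. It differs from compound 3 by iodo in place of bromo on an aromatic carbon. This is the same kind of change as that from compound 1 to compound 2, though the iodo now sits para rather than meta to the group of 6 heavy atoms. In this assay, within the data shown here, compound 4 is expected to show a step of a 1.6-fold lower number from compound 3 to compound 4 (0.21 log units; within the scatter) because the one earlier instance of this change gave a 1.6-fold lower number from compound 1 to compound 2 (0.21 log units; within the scatter). Compound 4 is therefore estimated at 8500 nM, likely between 4000 nM and 18000 nM.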

Compound 4, half-maximal inhibitory concentration: 12500 nM
Compound 4: the middle estimate sits 1.5-fold (0.17 log units) below what was measured; the range from low to high includes it.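

In this assay, iodo in place of bromo on an aromatic carbon gives a 1.1-fold lower number from compound 3 to compound 4 (0.04 log units; within the scatter). Set beside the earlier instance of the same change, this step shows no difference that could be told from the ordinary spread of such measurements: the same change on two cores in this assay, a 1.6-fold lower number (0.21 log units; within the scatter) from compound 1 to compound 2 and a 1.1-fold lower number (0.04 log units; within the scatter) from compound 3 to compound 4, 1.5-fold (0.17 log units) apart, within the scatter of two such steps. The change thus carried over between these two cores without a detectable shift in its size, but each step is itself within the scatter, so the pairs do not establish that iodo and bromo differ on either core, and two pairs say nothing about whether the step would hold on any other core.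

The compounds shown carry only bromo or iodo on the aromatic ring, which leaves open what a nitrile, a methoxy group or an amine would give in the same place. Also open, on these data alone, is whether the dichloroacetamide part can be replaced, for instance by a plain acetamide, without losing the activity seen here.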